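The source may report more compounds than this note shows. Statements on the series, on what has been measured and on what is new or still open speak of the compounds shown alone.

Compound 1 `C=C1C(=O)O[C@H]2[C@H]1CC/C(COC(=O)Cn1cc(F)c(=O)n(Cc3ccc([N+](=O)[O-])cc3)c1=O)=C\CC[C@@]1(C)O[C@@H]21` gives 4070 nM
Compound 2 `C=C1C(=O)O[C@H]2[C@H]1CC/C(COC(=O)Cn1cc(F)c(=O)n(Cc3ccc(F)cc3F)c1=O)=C\CC[C@@]1(C)O[C@@H]21` gives 3670 nM

In a functional assay on Bel-7402 cells (Homo sapiens) for antiproliferative activity, read by MTT assay, with a stated time of 72 h (on this read-out higher numbers stand for weaker inhibition and lower numbers for stronger inhibition), compound 2 gives 3670 nM and stands level with compound 1 within the scatter. Compound 3 `C=C1C(=O)O[C@H]2[C@H]1CC/C(COC(=O)Cn1cc(F)c(=O)n(Cc3c(F)cccc3F)c1=O)=C\CC[C@@]1(C)O[C@@H]21` has the same atoms, joined differently: 2,6-difluorophenyl in place of 2,4-difluorophenyl on a saturated chain carbon bound to an aromatic nitrogen. Here 2,6-difluorophenyl takes the place of 2,4-difluorophenyl on a saturated chain carbon bound to an aromatic nitrogen. Among the measured compounds shown here, only one measured step bears on this change, a 1.1-fold lower number from compound 1 to compound 2 (0.04 log units; within the scatter), a swap of one ring group for another at the same place. On that evidence, no step beyond the scatter is expected in this assay. The estimated step is a 1.0-fold higher number from compound 2 to compound 3 (0.00 log units; within the scatter). For compound 3 the expected value is 3700 nM, with an estimated range from 1800 nM to 7500 nM.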

Compound 3, half-maximal inhibitory concentration: 4500 nM
The estimate for compound 3 lay 1.2-fold (0.09 log units) below the measured number; measured number inside the range.
By their numbers in this assay, from the lowest: compounds 2, 1 and 3 (each within the scatter of the next).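

In this assay, swapping 2,4-difluorophenyl for 2,6-difluorophenyl, which uses the same atoms joined differently, gives a 1.2-fold higher number from compound 2 to compound 3 (0.09 log units; within the scatter). Replacing 4-nitrophenyl with 2,6-difluorophenyl gives a 1.1-fold higher number from compound 1 to compound 3 (0.04 log units; within the scatter). Across these three ring groups on the saturated chain carbon bound to an aromatic nitrogen, every step lies within the scatter, so this assay separates none of them. No measurement shown explains this lack of separation. Still open, going by these compounds, is whether a longer chain in place of the ring, or a ring carrying an amine or a carboxylic acid, would shift the number.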